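This account rests on a few compounds, and the source may have more. Where it says the series, first, only, none or still open, it means among the compounds named here.

Compound 2 `Cc1cc(C(F)(F)F)c2nc(C3(c4ccc(Cl)cc4)CC3)c(O)c(C(=O)O)c2c1` stands highest of the two numbers in hand: in an assay on isolated protein for inhibition of P-selectin glycoprotein ligand 1 (Homo sapiens), read by surface plasmon resonance, tested at 250 uM (a higher number here means more inhibition at the concentration tested (going by the name of the read-out), a lower number less inhibition), compound 2 gives 65%. Compound 1 `CCc1cc(C(F)(F)F)c2nc(C3(c4ccccc4)CC3)c(O)c(C(=O)O)c2c1` gives 40% in this assay, a number lower than that of compound 2 by more than the usual scatter. Compound 1 and compound 2 differ from each other in more than one place, so no single change can be read from that pair; only the two values themselves stand. Compound 3 `CCc1cc(C(F)(F)F)c2nc(C3(c4ccc(Cl)cc4)CC3)c(O)c(C(=O)O)c2c1` is not yet measured in this assay. Compound 3 differs from compound 2 by methyl in place of hydrogen on a saturated chain carbon bound to an aromatic carbon. Within the data shown here, no measured pair isolates this change, so the series gives no direct reading of it. The step from compound 2 to compound 3 is expected to be a number 5 percentage points lower from compound 2 to compound 3 (within the scatter), which is not beyond the scatter, with no clear direction. Compound 3 is estimated to give 60% in this assay, with a range from 38% to 80%.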

Compound 3, a percentage reported as inhibition, at one concentration (the size of the read-out at that concentration, not a potency): <= 10%
Compound 3: only a limit was reported; the forecaster's own chance of this, stated with the estimate: 0%; middle value at least 50 percentage points from the limit.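

In this assay compound 3 gives <= 10%, which is a limit of the assay and not a number: the limit of <= 10% in this assay, at which 1 of the 3 values shown sits.
Methyl to ethyl on the saturated chain carbon bound to an aromatic carbon gives a number at least 55 percentage points lower from compound 2 to compound 3 (beyond the scatter), the first reading of this place in the series, and one added carbon there is enough for a large step. With ethyl held fixed, chloro in place of hydrogen on an aromatic carbon gives a number at least 30 percentage points lower from compound 1 to compound 3 (beyond the scatter), so in this pair the chloro change goes with a lower number.

The compounds shown leave open how a propyl chain or a hydroxymethyl group would read at this place. Whether chloro has the same effect with methyl in place cannot be read from them.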